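This account rests on a few compounds, and the source may have more. Where it says the series, first, only, none or still open, it means among the compounds named here.

Measured compounds:
compound 1, `CNC(=O)c1c(O)c2cccnc2n(-c2ccccc2)c1=O` — 21%
compound 2, `COc1ccc(NC(=O)c2c(O)c3cccnc3n(-c3ccccc3)c2=O)cc1` — -1.9%
compound 3, `O=C(Nc1cccc(Cl)c1)c1c(O)c2cccnc2n(-c2ccccc2)c1=O` — 13.4%

In a functional assay on the whole organism for inhibition, with Rattus norvegicus as the target, read by cytopathic effect and paw edema, at a dose of 100 mg/kg by the oral route (a higher number here means more inhibition at the dose given (going by the name of the read-out), a lower number less inhibition), compound 3 has the second highest of the three numbers. Its nearest neighbour is compound 1, with a number 7.6 percentage points lower from compound 1 to compound 3 (within the scatter); its furthest is compound 2, with a number 15.3 percentage points higher from compound 2 to compound 3 (beyond the scatter). Compound 4, `O=C(Nc1cccc([N+](=O)[O-])c1)c1c(O)c2cccnc2n(-c2ccccc2)c1=O`, differs from compound 3 by nitro in place of chloro on an aromatic carbon. Among the measured compounds shown here, the step that bears most directly on this is the one from compound 2 to compound 3, where one aryl group on the amide nitrogen was exchanged for another and gave a number 15.3 percentage points higher from compound 2 to compound 3 (beyond the scatter); the other two steps replaced methyl by an aryl group, with a number 22.9 percentage points lower from compound 1 to compound 2 (beyond the scatter) and a number 7.6 percentage points lower from compound 1 to compound 3 (within the scatter). Exchanging one substituent on the ring for another has so far moved the read-out only modestly, so a small step, a number 3.4 percentage points lower from compound 3 to compound 4 (within the scatter), is expected, with no clear direction. For compound 4 the estimate is 10%, ranging from -8% to 28%.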

Compound 4, a percentage reported as inhibition, in the whole organism at one dose (the size of the read-out at that dose, not a potency): 7.4%
For compound 4 the middle estimate is 2.6 percentage points above the measured one; the range from low to high includes it.
By their numbers in this assay, from the lowest: compounds 2, 4, 3 and 1 (each within the scatter of the next, the first and the last beyond it).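

Swapping chloro for nitro on the aromatic ring leaves the result in this assay within the scatter, with a number 6 percentage points lower from compound 3 to compound 4 (within the scatter), so these two groups cannot be told apart here. The 3-nitrophenyl amide can be told apart from the methyl amide, with a number 13.6 percentage points lower from compound 1 to compound 4 (beyond the scatter), but not from the 4-methoxyphenyl amide, with a number 9.3 percentage points higher from compound 2 to compound 4 (within the scatter). No measurement offered here accounts for these results.

Still open, on these data alone, is how an amine or a carboxylic acid would read at this ring position. Also open, as far as these compounds go, is how a longer chain would read on the amide nitrogen in place of methyl.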